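Benzyl-ring swap on a fatty-chain lactone: from chloro to methyl

The compounds below may be only part of what the source reports. "The series", "measured", "known", "first", "only" and "open" are said of these compounds alone.

Measured so far:
Compound 1, `CCCCCCCCCCCCCCCC(NCc1ccccc1O)=C1C(=O)OC(CO)C1=O` – > 100000 nM
Compound 2, `CCCCCCCCCCCCCCCC(NCc1cccc(Cl)c1)=C1C(=O)OC(CO)C1=O` – > 100000 nM

Of the compounds shown here, two with a shared core have been tested in an assay on isolated protein for inhibition of dual specificity protein phosphatase 1 (Homo sapiens); on this read-out higher numbers stand for weaker inhibition and lower numbers for stronger inhibition. Compound 1 is `CCCCCCCCCCCCCCCC(NCc1ccccc1O)=C1C(=O)OC(CO)C1=O`, and in this assay compound 1 reaches only a limit of the assay, > 100000 nM. Compound 2 is `CCCCCCCCCCCCCCCC(NCc1cccc(Cl)c1)=C1C(=O)OC(CO)C1=O`, and in this assay compound 2 likewise reaches only a limit, > 100000 nM. Among the measured compounds shown here, the single measured step, a step that the two limits leave unreadable from compound 1 to compound 2, therefore cannot be read, since both ends sit at the same limit, as the limit of > 100000 nM in this assay, at which 2 of the 2 values shown sit, records.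

Compound 3 is `CCCCCCCCCCCCCCCC(NCc1ccc(C)cc1)=C1C(=O)OC(CO)C1=O`. The change from compound 2 is 4-methylphenyl in place of 3-chlorophenyl on a saturated chain carbon bound to an amine nitrogen. For the measured compounds named here, no measured step says anything about what such a swap does on this core, and the one step that exists is unreadable. Going by the values given here, the only thing the numbers show is that compound 2 sits at the limit in this assay, which leaves the expected step that the limit leaves unreadable from compound 2 to compound 3 most likely to end at the same limit again. Compound 3 is therefore expected to give about 150000 nM, with a range from 40000 nM to 600000 nM.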

Compound 3, half-maximal inhibitory concentration: > 100000 nM
Compound 3 ended at the assay's limit; the forecaster's own chance of this, stated with the estimate: 85%; the middle value is on the limit's open side.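

In this assay compound 3 gives > 100000 nM, which is a limit of the assay and not a number. The steps among compound 1, compound 2 and compound 3 cannot be read, because all three share one result: the limit of > 100000 nM in this assay, at which 3 of the 3 values shown sit. The compounds shown leave open how the three compare and whether any group at this place on the shared core gives a measurable value.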